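Swapping the butyl for cyclopropylmethyl on the aromatic nitrogen

This account rests on a few compounds, and the source may have more. Where it says the series, first, only, none or still open, it means among the compounds named here.

Measured compounds:
- compound 1 `Cc1ccc(-c2nn(-c3ccc(F)cc3)cc2C(=O)Nc2ccc(C)c(S(=O)(=O)N3CCOCC3)c2)cc1` gives 24.3 nM in an assay on isolated protein for antagonist activity at Bile acid receptor (Homo sapiens), read by TR-FRET, with a stated time of 20 min; on this read-out higher numbers stand for weaker inhibition and lower numbers for stronger inhibition
- compound 2 `CCCCn1cc(C(=O)Nc2ccc(C)c(S(=O)(=O)N3CCOCC3)c2)c(-c2ccc(C)cc2)n1` gives 52.5 nM in this assay

Among the measured compounds shown here, compound 2 stands at the higher of the two numbers so far. For the measured compounds named here, its nearest neighbour is compound 1, and the only measured step, a 2.2-fold higher number from compound 1 to compound 2 (0.33 log units; beyond the scatter), is of modest size and lies beyond the scatter; it concerns the group on the aromatic nitrogen.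

Compound 3 `Cc1ccc(-c2nn(CC3CC3)cc2C(=O)Nc2ccc(C)c(S(=O)(=O)N3CCOCC3)c2)cc1` differs from compound 2 at the same position, but in a different way: cyclopropyl in place of propyl on a saturated chain carbon bound to an aromatic nitrogen. Read one bond further out, this is butyl giving way to cyclopropylmethyl. Going by the values given here, no measured step bears directly on such a change; the one step available, a 2.2-fold higher number from compound 1 to compound 2 (0.33 log units; beyond the scatter), replaces an aromatic ring with a chain and is not a close model for a chain being closed into a small ring of the same size.

On that basis compound 3 is expected to stay close to compound 2, with a step of a 1.2-fold lower number from compound 2 to compound 3 (0.07 log units; within the scatter) that need not exceed the scatter. The estimate for compound 3 in this assay is 45 nM, within a range from 20 nM to 110 nM.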

Compound 3, half-maximal inhibitory concentration: 76.9 nM
The estimate for compound 3 lay 1.7-fold (0.23 log units) below the measured number; measured number inside the range.
By their numbers in this assay, from the lowest: compound 1; then compounds 2 and 3 (each within the scatter of the next).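

In this assay, closing the butyl chain into cyclopropylmethyl on the aromatic nitrogen gives a 1.5-fold higher number from compound 2 to compound 3 (0.17 log units; within the scatter), so this change does not separate the two compounds, and on these two examples the assay does not distinguish the open chain from the small ring at this position. The comparison with the aromatic substituent now rests on two different groups: a 3.2-fold higher number from compound 1 to compound 3 (0.50 log units; beyond the scatter), alongside a 2.2-fold higher number from compound 1 to compound 2 (0.33 log units; beyond the scatter), leaves compound 1 with the lowest number of the three, and its steps to both compound 2 and compound 3 lie beyond the scatter. No measurement is available to explain this difference between 4-fluorophenyl and the two saturated groups.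

The compounds shown leave open whether the fluorine contributes, since a plain phenyl on the aromatic nitrogen would be needed to separate it from the ring that carries it, and whether a benzyl group, with a single carbon set before the aromatic ring, would fall with compound 1 or with compound 3. They also leave open how a shorter chain such as methyl, or a chain ending in an amine or a carboxylic acid, would read at this position.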